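The source may report more compounds than this note shows. Statements on the series, on what has been measured and on what is new or still open speak of the compounds shown alone.

Three compounds share one core and differ only in the group on one nitrogen. Compound 1 `COc1ccc(Nc2nc(NC3CCCC3)c3ccccc3n2)cc1` gives 12400 nM in a functional assay on DU-145 cells (Homo sapiens) for antiproliferative activity, read by sulforhodamine B assay, with a stated time of 48 h; a lower number here means a stronger inhibitor of growth, a higher number a weaker inhibitor of growth. Compound 2 `COc1ccc(Nc2nc(NCCCO)c3ccccc3n2)cc1` gives 18300 nM in this assay, and compound 3 `COc1ccc(Nc2nc(NC3CC3)c3ccccc3n2)cc1` gives 13000 nM. The steps of a 1.5-fold higher number from compound 1 to compound 2 (0.17 log units; within the scatter) and a 1.0-fold higher number from compound 1 to compound 3 (0.02 log units; within the scatter) both stay within the scatter, as does a 1.4-fold lower number from compound 2 to compound 3 (0.15 log units; within the scatter). Compound 1 shows the lowest of the three numbers, yet all three sit within the scatter of one another, so no order among them can be claimed. Compound 4 `O=C(O)c1ccc(Nc2nc(NC3CCCC3)c3ccccc3n2)cc1` keeps the cyclopentyl group of compound 1 and changes at a different place: carboxy in place of methoxy on an aromatic carbon. Going by the values given here, none of the measured steps touches this position, so they bear on it only by showing that the shared core gives much the same number whatever the change made so far. Among the compounds with values here, with no measured step for a carboxy group, the expectation for compound 4 is no step beyond the scatter, and a 1.2-fold higher number from compound 1 to compound 4 (0.08 log units; within the scatter) is expected to be small. Compound 4 is estimated at 15000 nM, with a range from 5000 nM to 45000 nM.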

Compound 4, concentration for 50% growth inhibition: 27300 nM
Compound 4: middle estimate off by 1.8-fold (0.26 log units), on the low side; the range from low to high includes it.
By their numbers in this assay, from the lowest: compounds 1, 3, 2 and 4 (each within the scatter of the next, the first and the last beyond it).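

Carboxy in place of methoxy, on an aromatic carbon para to a large group, gives a 2.2-fold higher number from compound 1 to compound 4 (0.34 log units; beyond the scatter) in this assay. Going by these compounds alone, this is the first single change in the set to go beyond the scatter, since the three steps among the groups on the nitrogen all stay within it, so the number does respond to a change at this position, if only modestly. Nothing shown here reveals the reason for this step.

From the compounds shown here alone, it remains open whether a methyl ester, a primary amide or a plain hydrogen at this carbon would give a number nearer that of compound 1 or that of compound 4. Also open, going by these compounds, is whether carboxy would give a similar step with 3-hydroxypropyl or cyclopropyl on the nitrogen in place of cyclopentyl.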